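Removing the benzyl group from the amide of compound 2

The compounds below may be only part of what the source reports. "The series", "measured", "known", "first", "only" and "open" are said of these compounds alone.

Measured so far:
compound 1 `COc1ccc(-c2nn3c(C)cc(C)nc3c2CC(=O)N(C)Cc2ccccc2)cc1` 9.3 nM
compound 2 `CCN(Cc1ccccc1)C(=O)Cc1c(-c2ccc(OC)cc2)nn2c(C)cc(C)nc12` 6.2 nM

Among the measured compounds shown here, in an assay on HEK293T cells for displacement of a labelled ligand from Translocator protein (Homo sapiens), read by scintillation counting, with a stated time of 90 min (on this read-out higher numbers stand for weaker inhibition and lower numbers for stronger inhibition), compound 2 gives 6.2 nM, the lowest of the two numbers; its only neighbour is compound 1, and the step of a 1.5-fold lower number from compound 1 to compound 2 (0.18 log units; within the scatter) lies within the scatter. Compound 3 `COc1ccc(-c2nn3c(C)cc(C)nc3c2CC(=O)N(C)C)cc1` differs from compound 2 by dimethylamino in place of benzyl(ethyl)amino on a carbonyl carbon. No measured step bears on this change; the one step shown, a 1.5-fold lower number from compound 1 to compound 2 (0.18 log units; within the scatter), concerns a smaller alteration on the same nitrogen. The expected step of a 9.7-fold higher number from compound 2 to compound 3 (0.99 log units; beyond the scatter) is therefore uncertain and is expected to run toward a higher number. Compound 3 is estimated at 60 nM, with a range from 10 nM to 400 nM.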

Compound 3, inhibition constant: 338 nM
Compound 3: the middle estimate sits 5.6-fold (0.75 log units) below what was measured, within the range that was stated.
By their numbers in this assay, from the lowest: compounds 2 and 1 (each within the scatter of the next); then compound 3.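

In this assay, the amide substituent proves far more sensitive than the earlier pair could show: replacing phenyl with hydrogen on the saturated chain carbon bound to the amide-type nitrogen is a large change (a 36-fold higher number from compound 1 to compound 3 (1.56 log units; beyond the scatter)), and replacing benzyl(ethyl)amino with dimethylamino is similarly large (a 55-fold higher number from compound 2 to compound 3 (1.74 log units; beyond the scatter)). Both low numbers thus belong to compounds carrying the benzyl group. Nothing available explains the size of this loss. Still open, as far as these compounds go, is whether a cyclohexyl or pyridyl ring in place of phenyl, or a butyl chain without any ring, would keep the number low.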